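From compound 2 to its amino relative, compound 3

A few compounds are considered here, and "the series" means these few. Any claim that something is new, unique, unknown or untested is made for them only; others in the source may bear on it.

Compound 1 `Cc1ccc(-c2nn(-c3cccc(Cl)c3)c(/N=C/N(C)C)c2C=O)cc1`: 7200 nM
Compound 2 `CN(C)/C=N/c1c(C=O)c(-c2ccc(Cl)cc2)nn1-c1cccc(Cl)c1`: 7400 nM

In a functional assay on NPC-TW01 cells (Homo sapiens) for inhibition, read by MTT assay, with a stated time of 72 h (a lower number here means a stronger inhibitor of growth, a higher number a weaker inhibitor of growth), compound 2 gives 7400 nM, a number that cannot be told apart from compound 1 at 7200 nM. Compound 3 `Nc1c(C=O)c(-c2ccc(Cl)cc2)nn1-c1cccc(Cl)c1` keeps the rest of compound 2 but carries an amino group in place of a larger chain: one nitrogen atom in place of a group of 5 heavy atoms (3 carbon, 2 nitrogen; no ring), on an aromatic carbon. For the measured compounds named here, the only measured step, a 1.0-fold higher number from compound 1 to compound 2 (0.01 log units; within the scatter), lies within the scatter. Going by the values given here, it swaps chloro for methyl elsewhere on the molecule, so it says little about this change, and no measured compound carries the amino group. A change this large is still expected to shift the number, probably towards weaker growth inhibition, though the data cannot confirm this. The expected step is a 2.0-fold higher number from compound 2 to compound 3 (0.31 log units; beyond the scatter). The estimate for compound 3 is 15000 nM, with an expected range of 4000 nM to 50000 nM.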

Compound 3, concentration for 50% growth inhibition: > 100000 nM
Compound 3: no number, only a limit; the forecaster's own chance of this, stated with the estimate: 25%; middle value at least 6.6-fold (0.82 log units) away from the limit.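

Putting amino in place of the group of 5 heavy atoms on this aromatic carbon gives an at least 13-fold higher number from compound 2 to compound 3 (1.13 log units; beyond the scatter) in this assay, so growth inhibition here depends strongly on what this position carries. For the compounds shown here, the only other step, a 1.0-fold higher number from compound 1 to compound 2 (0.01 log units; within the scatter), swaps chloro for methyl elsewhere on the molecule and gave no sign that one change could matter this much. The value of compound 3 is a limit of the assay and not a number, so the full size of the step stays unknown: the limit of > 100000 nM in this assay, at which 1 of the 3 values shown sits.

Nothing shown tells how a methylamino or dimethylamino group on this aromatic carbon would read, so it stays open whether any simpler group can keep the growth inhibition of compound 2. On these data alone, it also stays open whether amino would read the same with a nitrile or a carboxylic acid in place of the formyl group.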